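Oxime oxygen substituent swap on the diaryl thioether series

The source may hold more compounds than are shown below. What is called first, only, known or untested is meant among the compounds shown, and "the series" means these compounds.

Measured so far in a functional assay (blood) for inhibition, with Homo sapiens as the target; on this read-out lower numbers stand for stronger inhibition and higher numbers for weaker inhibition:
- compound 1 `CCOC(=O)CO/N=C(\C)c1ccc(Sc2cc(F)cc(C3CCOCC3)c2)cc1`: 610 nM
- compound 2 `COC1(c2csc(Sc3ccc4c(c3)OCC/C4=N\OCC#N)c2)CCOCC1`: 60 nM
- compound 3 `CO[C@]1(c2cnc(Sc3ccc(/C(C)=N/OCC#N)cc3)s2)CCO[C@@H](C)C1`: 40 nM

Compound 1 gives the highest number of the three. Compound 2 sits a clear margin lower, beyond the scatter, and compound 3 lower still, also beyond the scatter; compounds 2 and 3 are built on different cores, so their numbers say nothing about a single change from compound 1. Among the compounds with values here, no pair among the three differs in one place, so no measured step is available.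

Compound 4 `C/C(=N\OC(=O)N(C)C)c1ccc(Sc2cc(F)cc(C3CCOCC3)c2)cc1` keeps the core of compound 1 and differs from it in one place: dimethylcarbamoyl in place of (ethoxycarbonyl)methyl on an oxygen. The oxygen carrying the change is the one bonded to the double-bonded nitrogen. Nothing measured here shows what this kind of exchange does in this assay, so the expectation rests on compound 1 alone. With no guidance, the step is expected to stay close to the scatter, with no strong lean in either direction, though the range allowed is wide.

Compound 4 is therefore estimated at 500 nM, within 150 nM to 2000 nM, which means an expected step of a 1.2-fold lower number from compound 1 to compound 4 (0.09 log units; within the scatter).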

Compound 4, half-maximal inhibitory concentration: 2610 nM
The estimate for compound 4 lay 5.2-fold (0.72 log units) below the measured number, outside the stated range (above it).
By their numbers in this assay, from the lowest: compounds 3 and 2 (each within the scatter of the next); then compound 1; then compound 4.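

Within the data shown here, on the oxygen bonded to the double-bonded nitrogen, dimethylcarbamoyl in place of (ethoxycarbonyl)methyl gives a 4.3-fold higher number from compound 1 to compound 4 (0.63 log units; beyond the scatter) in this assay and provides the first measured single-place step in this set, showing that the group on this oxygen matters on the core of compound 1. The exchange is modest by count, with 6 heavy atoms leaving and 5 entering, neither group bearing a ring or a hydrogen-bond donor, yet the step lies beyond the scatter and runs toward weaker inhibition. Nothing available explains this shift, which remains a single observation on one core.

Still open, as far as these compounds go, is whether the weaker inhibition follows the dimethylcarbamoyl unit itself or the change from (ethoxycarbonyl)methoxy to (dimethylcarbamoyl)oxy, in which the carbonyl comes to sit directly on the oxygen. A (dimethylcarbamoyl)methyl group on the same oxygen would separate those two readings, while a carboxymethyl group or a longer ester chain would test how much of the number of compound 1 depends on the ethyl ester.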